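This account rests on a few compounds, and the source may have more. Where it says the series, first, only, none or still open, it means among the compounds named here.

Measured so far in a functional assay on MIA PaCa-2 cells (Homo sapiens) for inhibition, read by MTT assay, with a stated time of 7 days; a lower number here means a stronger inhibitor, a higher number a weaker inhibitor:
compound 1 `CCN(CC)S(=O)(=O)c1ccc(S(=O)(=O)N2CCC[C@@H](C(=O)NC3COC3)C2)cc1` gives 2300 nM
compound 2 `CCN(CC)S(=O)(=O)c1ccc(S(=O)(=O)N2CCC[C@@H](C(=O)NC3CN(C(=O)NC(C)(C)C)C3)C2)cc1` gives 3400 nM
compound 3 `CCN(CC)S(=O)(=O)c1ccc(S(=O)(=O)N2CCC[C@@H](C(=O)N3CCN(c4nc(C)no4)CC3)C2)cc1` gives 250 nM

Compound 3 has the lowest number of the three, and its gaps to the other two lie beyond the scatter. Compound 4 `CCN(CC)S(=O)(=O)c1ccc(S(=O)(=O)N2CCC[C@@H](C(=O)N3CCN(C(=O)OC(C)(C)C)CC3)C2)cc1` carries tert-butoxycarbonyl in place of 3-methyl-1,2,4-oxadiazol-5-yl on an amine nitrogen in a ring. Within the data shown here, no measured step changes this group alone. The nearest evidence is a 9.2-fold lower number from compound 1 to compound 3 (0.96 log units; beyond the scatter) and a 14-fold lower number from compound 2 to compound 3 (1.13 log units; beyond the scatter) but both replace the whole amine part of the amide, while a 1.5-fold higher number from compound 1 to compound 2 (0.17 log units; within the scatter) shows little change. Compound 4 keeps that ring, so only a small rise in the number is expected, estimated as a 1.6-fold higher number from compound 3 to compound 4 (0.20 log units; within the scatter) and not clearly beyond the scatter. Compound 4 is estimated at 400 nM (120 nM to 1400 nM).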

Compound 4, half-maximal inhibitory concentration: 70 nM
Beside the measured number, compound 4's estimate is 5.7-fold (0.76 log units) above it; the whole stated range lies above it.
By their numbers in this assay, from the lowest: compound 4; then compound 3; then compounds 1 and 2 (each within the scatter of the next).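

In this assay, among these compounds, tert-butoxycarbonyl in place of 3-methyl-1,2,4-oxadiazol-5-yl gives a 3.6-fold lower number from compound 3 to compound 4 (0.55 log units; beyond the scatter), the first measured change of a single group on this amine nitrogen in a ring. It shows that the number responds to this group alone, with the rest of the amine part kept, and that a five-membered aromatic ring is not needed here for a low number. No measurement shown explains the step. The compounds shown leave open whether the step follows the carbonyl or the tert-butyl part, which an acetyl group or a lone tert-butyl group on this nitrogen would separate.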